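Trading a Benzyl Group for Propyl on a Ring Amine

This account rests on a few compounds, and the source may have more. Where it says the series, first, only, none or still open, it means among the compounds named here.

Of the compounds shown here, two have been tested in a functional assay on ileum for inhibition of histamine H1 receptor (Cavia porcellus); on this read-out higher numbers stand for weaker inhibition and lower numbers for stronger inhibition. Compound 1 `CCOCCn1c(N2CCCN(Cc3ccccc3)CC2)nc2ccccc21` gives 15 nM in this assay, the lowest of the two numbers. Compound 2 `CCCSCn1c(N2CCN(C)CC2)nc2ccccc21` gives 68 nM in this assay, a weaker inhibition than compound 1 by a margin beyond the usual scatter. The two differ in more than one place, so their gap cannot be tied to any single change.

Compound 3 `CCCN1CCCN(c2nc3ccccc3n2CCOCC)CC1` is the next compound, not yet measured in this assay. It differs from compound 1 in one place only: ethyl in place of phenyl on a saturated chain carbon bound to an amine nitrogen in a ring. Cut one bond further out, the same difference reads benzyl to propyl.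

Going by the values given here, no measured pair shows this change, so the size of the step is open. The phenyl that leaves is a large part of the group attached to the ring amine, and its loss is expected to cost some inhibition, with the step from compound 1 to compound 3 estimated at a 2.7-fold higher number from compound 1 to compound 3 (0.43 log units; beyond the scatter), a modest weakening that may still fall near the scatter. Compound 3 is therefore expected to give about 40 nM in this assay, with a range from 12 nM to 130 nM.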

Compound 3, half-maximal inhibitory concentration: 8.4 nM
Estimate against measurement, compound 3: 4.8-fold (0.68 log units) above, and the stated range ends above it.
By their numbers in this assay, from the lowest: compounds 3 and 1 (each within the scatter of the next); then compound 2.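

Going from benzyl to propyl on the ring amine gives a 1.8-fold lower number from compound 1 to compound 3 (0.25 log units; within the scatter) in this assay and so places the two compounds level with each other. Going by these compounds alone, this is the first direct look at this position, and it shows that a six-membered aromatic ring of carbon can leave the group without a change that stands clear of the usual scatter: with the core and the ethoxyethyl side unchanged, a plain saturated chain serves as well as benzyl in this assay. Nothing measured on these compounds accounts for why the exchange makes so little difference.

On these data alone, with only benzyl and propyl compared on this ring amine, it remains open how far the group can vary before inhibition shifts, whether towards a longer chain such as butyl, a saturated ring such as cyclohexylmethyl, or a chain carrying a hydroxyl. Compound 2 cannot help settle this, as it differs from compound 1 and compound 3 in more than one place, so its number cannot be tied to the group on the ring amine alone.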